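This account rests on a few compounds, and the source may have more. Where it says the series, first, only, none or still open, it means among the compounds named here.

Measured so far:
- compound 1 `CCC(c1ccccc1)c1nc2c(C(F)(F)F)cccc2c(C(=O)O)c1O`: 600 ug/mL
- compound 2 `CC(C)C(c1ccccc1)c1nc2c(C(F)(F)F)cccc2c(C(=O)O)c1O`: 30 ug/mL

In a physicochemical assay for solubility, at pH 6.6 (on this read-out lower numbers stand for lower solubility and higher numbers for higher solubility), compound 1 gives 600 ug/mL, the higher of the two numbers available. Compound 3 `CC(Cc1nc2c(C(F)(F)F)cccc2c(C(=O)O)c1O)c1ccccc1` has the same atoms as compound 1, joined differently: 2-phenylpropyl in place of 1-phenylpropyl on an aromatic carbon. In words, 2-phenylpropyl stands in place of 1-phenylpropyl on an aromatic carbon next to the ring nitrogen.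

Going by the values given here, only one measured step bears on this: a 20-fold lower number from compound 1 to compound 2 (1.30 log units; beyond the scatter). This large step, beyond the scatter, puts methyl in place of hydrogen on a saturated chain carbon bound to two saturated chain carbons. Among the compounds with values here, it is a different change, as compound 3 adds no atoms, and no measured pair shows a rearrangement of this kind. It therefore serves as a warning, not a measure: in this one case, an edit on the chain moved the number a long way.

Within the data shown here, with compound 1 at 600 ug/mL and the only measured step going down, a moderate fall seems the likeliest outcome. The expected change is a 2.4-fold lower number from compound 1 to compound 3 (0.38 log units; beyond the scatter), smaller than the measured step but uncertain. For compound 3 the estimated value is 250 ug/mL, with an expected range from 60 ug/mL to 800 ug/mL.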

Compound 3, solubility: 680 ug/mL
Estimate against measurement, compound 3: 2.7-fold (0.43 log units) below, within the range that was stated.
By their numbers in this assay, from the lowest: compound 2; then compounds 1 and 3 (each within the scatter of the next).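

In this assay, 2-phenylpropyl in place of 1-phenylpropyl on the aromatic carbon next to the ring nitrogen gives a 1.1-fold higher number from compound 1 to compound 3 (0.05 log units; within the scatter), so the two numbers cannot be told apart. The earlier compounds shown here offered a single chain edit, the added methyl, with a 20-fold lower number from compound 1 to compound 2 (1.30 log units; beyond the scatter), and they could have suggested that any edit of this chain moves the number a long way; compound 3 shows that at least one rearrangement of the same atoms at this position does not. No measurement here accounts for the contrast between these two edits, so it stands as an observation without an explanation.

From the compounds shown here alone, only these two edits of the chain are on view, so it remains open how a shorter group such as benzyl, or the straight 3-phenylpropyl, would read in this assay. Also open, going by these compounds, is whether an amine or a hydroxy group on the chain, or a substituent on its phenyl ring, would leave the number within the scatter of compound 1 or shift it as far as the added methyl did.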